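A few compounds are considered here, and "the series" means these few. Any claim that something is new, unique, unknown or untested is made for them only; others in the source may bear on it.

- Compound 1 `CC1(C)CC(NC(=S)Nc2cccc([N+](=O)[O-])c2)c2cc(Br)ccc2O1`: 4000 nM
- Compound 2 `CC1(C)CC(NC(=S)Nc2cccc(Cl)c2)c2cc(Br)ccc2O1`: 9000 nM
- Compound 3 `CC1(C)CC(NC(=O)NCc2ccccc2)c2cc(F)ccc2O1`: 49000 nM

All three values come from a functional assay on T98G cells (Homo sapiens) for inhibition, read by MTT assay, with a stated time of 72 h; a higher number here means a weaker inhibitor, a lower number a stronger inhibitor. Compound 2, at 9000 nM, sits in the middle of the three: compound 1 has the lowest number and compound 3 the highest. The next compound, compound 4 `CC1(C)CC(NC(=S)Nc2ccc(Cl)cc2)c2cc(Br)ccc2O1`, has not yet been measured. It keeps the same atoms as compound 2 but joins them differently, with 4-chlorophenyl in place of 3-chlorophenyl on an amide-type nitrogen.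

For the measured compounds named here, only one measured step bears on this part of the molecule. That step, a 2.3-fold higher number from compound 1 to compound 2 (0.35 log units; beyond the scatter), was modest and put chloro in place of nitro on an aromatic carbon. It is a different kind of change, so it suggests a rough size but no direction. Compound 3 differs from compound 2 in more than one place and offers little guidance.

The expected change, a 1.1-fold lower number from compound 2 to compound 4 (0.05 log units; within the scatter), is not expected to exceed the scatter. For compound 4 the estimated value is 8000 nM, with an expected range of 3000 nM to 20000 nM.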

Compound 4, half-maximal inhibitory concentration: 22000 nM
The estimate for compound 4 lay 2.8-fold (0.44 log units) below the measured number; the measured number lies above the stated range.
By their numbers in this assay, from the lowest: compound 1; then compound 2; then compound 4; then compound 3.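

In this assay, a 2.4-fold higher number from compound 2 to compound 4 (0.39 log units; beyond the scatter), although the two compounds hold the same atoms and differ only in 3-chlorophenyl versus 4-chlorophenyl on the amide-type nitrogen. This shows that where the chloro group sits on the phenyl ring matters, not just whether it is present, and here the 3-chlorophenyl compound is the stronger of the pair. The earlier step from nitro to chloro could not show this, as it swapped one group for another, and nothing available here explains why the two chlorophenyl groups differ.

Going by these compounds, whether a methoxy group or an amine on the phenyl ring would depend on its place in the same way remains open. Also open, on these data alone, is whether the gap between compound 2 and compound 4 would persist on a core carrying a different group in place of the bromo.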